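Fluorine pattern on the aryl of the ring amine

A few compounds are considered here, and "the series" means these few. Any claim that something is new, unique, unknown or untested is made for them only; others in the source may bear on it.

In a functional assay on CHO cells with adenosine receptor A1 (Homo sapiens) as the target, read by cAMP accumulation and immunoassay, with a stated time of 6 min, tested at 0.01 uM (on this read-out lower numbers stand for a stronger effect and higher numbers for a weaker effect at the one concentration tested), compound 1 `CC(C)N1CCN(Cc2csc(N)c2C(=O)c2ccc(Cl)cc2)CC1` gives -1% and compound 2 `Nc1scc(CN2CCN(c3cc(F)cc(F)c3)CC2)c1C(=O)c1ccc(Cl)cc1` gives -13%. Compound 2 thus stands at the lower of the two numbers, with compound 1 its nearest neighbour, the step being a number 12 percentage points lower from compound 1 to compound 2 (beyond the scatter). Compound 3 `Nc1scc(CN2CCN(c3c(F)cc(F)cc3F)CC2)c1C(=O)c1ccc(Cl)cc1` differs from compound 2 by 2,4,6-trifluorophenyl in place of 3,5-difluorophenyl on an amine nitrogen in a ring. Within the data shown here, that single measured step concerns a different exchange, so no measured step bears on the present one. The expectation is therefore a step within the scatter, a number 2 percentage points higher from compound 2 to compound 3 (within the scatter). Compound 3 is estimated at -11%, between -25% and 4%.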

Compound 3, a percentage reported as activity, at one concentration (the size of the read-out at that concentration, not a potency): 4.2%
Compound 3: middle estimate off by 15.2 percentage points, on the low side, and the stated range ends below it.
By their numbers in this assay, from the lowest: compound 2; then compounds 1 and 3 (each within the scatter of the next).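

In this assay the fluorine pattern on the aryl at this ring amine counts: the exchange gives a number 17.2 percentage points higher from compound 2 to compound 3 (beyond the scatter) and so the lower number seen with 3,5-difluorophenyl does not extend to every fluorinated phenyl. Set against isopropyl, 2,4,6-trifluorophenyl gives a number 5.2 percentage points higher from compound 1 to compound 3 (within the scatter) so this aryl does not separate from the small alkyl group at this position. Nothing measured here accounts for the difference between the two fluorine patterns. Going by these compounds, whether the step follows the number of fluorines or their placement stays open. So does the reading of an unsubstituted phenyl or a benzyl group on this nitrogen.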